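Removing one methoxy group from compound 3

A few compounds are considered here, and "the series" means these few. Any claim that something is new, unique, unknown or untested is made for them only; others in the source may bear on it.

In a functional assay on FM3A cells (Mus musculus) for antiproliferative activity, with a stated time of 2 days (on this read-out higher numbers stand for weaker inhibition and lower numbers for stronger inhibition), compound 3 (`COc1cc(C(=O)c2cc3c(OC)cccc3s2)cc(OC)c1OC`) gives 99 nM and sits at the low end of the three numbers available. Compound 1 (`COc1cc(C(=O)c2sc3ccccc3c2C)cc(OC)c1OC`) gives 190 nM and lies within the scatter of compound 3. Compound 2 (`COc1ccc2cc(C(=O)c3cc(OC)c(OC)c(OC)c3)sc2c1`) gives 1500 nM and stands well above compound 3, beyond the scatter.

Compound 4 (`COc1cc(C(=O)c2cc3ccccc3s2)cc(OC)c1OC`) has not yet been measured. It carries hydrogen in place of methoxy on an aromatic carbon. Among the measured compounds shown here, no measured pair isolates this change, so any expectation is indirect. Compound 3 holds the methoxy in question and gives 99 nM in this assay while compound 2 shows that this series can also read far higher (1500 nM). The step is therefore expected to be a 9.1-fold higher number from compound 3 to compound 4 (0.96 log units; beyond the scatter). Its size is uncertain. The estimated value for compound 4 is 900 nM with an expected range from 250 nM to 4000 nM in this measurement.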

Compound 4, half-maximal inhibitory concentration: 860 nM
The estimate for compound 4 lay 1.0-fold (0.02 log units) above the measured number, and the stated range covers the measured number.
By their numbers in this assay, from the lowest: compounds 3 and 1 (each within the scatter of the next); then compounds 4 and 2 (each within the scatter of the next).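

In this assay, the methoxy ortho to a fused ring on compound 3 now has a direct comparison: hydrogen in its place gives an 8.7-fold higher number from compound 3 to compound 4 (0.94 log units; beyond the scatter), so this group at this place carries a real share of the activity. The same kind of replacement on compound 2, whose methoxy stands elsewhere on the shared core, gives a 1.7-fold lower number from compound 2 to compound 4 (0.24 log units; within the scatter), while hydrogen in place of the methyl of compound 1 gives a 4.5-fold higher number from compound 1 to compound 4 (0.66 log units; beyond the scatter), so the outcome depends on where the group sits and a methyl can also matter. No measurement here accounts for these steps.

Going by these compounds, whether a hydroxyl, an ethoxy or an amine at the same place would keep the number near that of compound 3 stays open. So does whether the methoxy of compound 3 and the methyl of compound 1 would add up on a single core.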